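Notes on NIH3T3 cytotoxicity across a small analogue set

The compounds below may be only part of what the source reports. "The series", "measured", "known", "first", "only" and "open" are said of these compounds alone.

Measured compounds:
compound 1 `COc1ccc(-c2cs/c(=N/NC(=O)CSc3nnnn3-c3ccccc3)n2-c2ccccc2)cc1` gives 11.7 ug/mL in an ADME assay on NIH3T3 cells (Mus musculus) for cytotoxicity, read by MTT assay, with a stated time of 24 h; on this read-out higher numbers stand for weaker inhibition and lower numbers for stronger inhibition
compound 2 `Cn1cnnc1SCC(=O)N/N=c1/scc(-c2ccc(C#N)cc2)n1-c1ccccc1` gives 153 ug/mL
compound 3 `Cn1cnnc1SCC(=O)N/N=c1/scc(-c2ccc(Br)cc2)n1-c1ccccc1` gives 58.3 ug/mL

Compound 3 stands second highest of the three numbers. Among the compounds with values here, the only measured step, a 2.6-fold lower number from compound 2 to compound 3 (0.42 log units; beyond the scatter), covers bromo in place of cyano and does not touch the change now in question. Compound 1 carries methoxy at the same position but differs in its heterocycle, so its lower number against compound 3 is noted, not read as a step.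

Compound 4 `COc1ccc(-c2cs/c(=N/NC(=O)CSc3nncn3C)n2-c2ccccc2)cc1` differs from compound 3 by methoxy in place of bromo on an aromatic carbon. Within the data shown here, no measured step bears directly on this change, so only a modest shift toward a lower number is expected, a 1.9-fold lower number from compound 3 to compound 4 (0.29 log units; within the scatter). Compound 4 is therefore estimated at 30 ug/mL, within 10 ug/mL to 90 ug/mL.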

Compound 4, half-maximal inhibitory concentration: 167 ug/mL
The estimate for compound 4 lay 5.6-fold (0.75 log units) below the measured number, outside the stated range (above it).
By their numbers in this assay, from the lowest: compound 1; then compound 3; then compounds 2 and 4 (each within the scatter of the next).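

In this assay, with the 4-methyl-4H-1,2,4-triazol-3-yl group on the sulfur, 4-bromophenyl to 4-methoxyphenyl gives a 2.9-fold higher number from compound 3 to compound 4 (0.46 log units; beyond the scatter) rather than the drop that compound 1 hinted at, while a 1.1-fold higher number from compound 2 to compound 4 (0.04 log units; within the scatter) leaves methoxy level with cyano at this position. With methoxy held constant, the group on the sulfur can now be read alone: a 14-fold higher number from compound 1 to compound 4 (1.15 log units; beyond the scatter) is the largest step in the set. No measured evidence accounts for either result. Still open, on these data alone, is where an amine or a hydroxyl on this aromatic carbon would fall, and whether the change on the sulfur gives a similar step with bromo or cyano in place of methoxy.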